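Methoxy for trifluoromethyl on a second core

The compounds below may be only part of what the source reports. "The series", "measured", "known", "first", "only" and "open" are said of these compounds alone.

Three compounds were tested in a functional assay on HeLa cells (Homo sapiens) for antiproliferative activity, read by sulforhodamine B assay, with a stated time of 48 h; on this read-out lower numbers stand for stronger inhibition of growth and higher numbers for weaker inhibition of growth. Compound 1 `O=C(NCc1cn(Cc2ccc(C(F)(F)F)cc2)nn1)c1cn(-c2ccccc2)nc1-c1ccc(Cl)cc1` gives 1900 nM. Compound 2 `COc1ccc(Cn2cc(CNC(=O)c3cn(-c4ccccc4)nc3-c3ccc(Cl)cc3)nn2)cc1` gives 1400 nM, the change being (methoxy in place of trifluoromethyl on an aromatic carbon), a step of a 1.4-fold lower number from compound 1 to compound 2 (0.13 log units; within the scatter). Compound 3 `COc1ccc(-c2nn(-c3ccccc3)cc2C(=O)NCc2cn(Cc3ccc(C(F)(F)F)cc3)nn2)cc1` gives 6200 nM, the highest of the three, and it differs from compound 1 by methoxy in place of chloro on an aromatic carbon, a step of a 3.3-fold higher number from compound 1 to compound 3 (0.51 log units; beyond the scatter). Compound 4 `COc1ccc(Cn2cc(CNC(=O)c3cn(-c4ccccc4)nc3-c3ccc(OC)cc3)nn2)cc1` is not yet measured; it differs from compound 3 by methoxy in place of trifluoromethyl on an aromatic carbon, the same change as from compound 1 to compound 2, made on the core of compound 3, which differs from the core of compound 1 as described by methoxy in place of chloro on an aromatic carbon. The step is expected to resemble the earlier one, a 1.3-fold lower number from compound 3 to compound 4 (0.11 log units; within the scatter), because a 1.4-fold lower number from compound 1 to compound 2 (0.13 log units; within the scatter) was small. Compound 4 is thus estimated at 4800 nM, between 2400 nM and 9600 nM.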

Compound 4, concentration for 50% growth inhibition: 450 nM
Estimate against measurement, compound 4: 11-fold (1.03 log units) above; measured number below the stated range.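

Methoxy in place of trifluoromethyl on the core of compound 3 gives a 14-fold lower number from compound 3 to compound 4 (1.14 log units; beyond the scatter), so the small earlier step did not carry over to this core in this assay: the same change on two cores in this assay, a 1.4-fold lower number (0.13 log units; within the scatter) from compound 1 to compound 2 and a 14-fold lower number (1.14 log units; beyond the scatter) from compound 3 to compound 4, 10-fold (1.01 log units) apart, beyond the scatter of two such steps. Methoxy in place of chloro, with 4-methoxybenzyl kept in both compounds, gives a 3.1-fold lower number from compound 2 to compound 4 (0.49 log units; beyond the scatter), opposite in direction to the same change with 4-(trifluoromethyl)benzyl kept: the same change on two cores in this assay, a 3.3-fold higher number (0.51 log units; beyond the scatter) from compound 1 to compound 3 and a 3.1-fold lower number (0.49 log units; beyond the scatter) from compound 2 to compound 4, 10-fold (1.01 log units) apart, beyond the scatter of two such steps. The two changes therefore do not act independently across these four compounds, but this single set does not show why, nor whether the same dependence holds for other groups.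

The compounds shown leave open how a hydroxyl or a dimethylamino group would behave in place of the methoxy on the 4-methoxybenzyl group. They also leave open whether a fluoro group in place of the chloro would follow compound 2 or compound 4.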